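Swapping a chlorobenzylamino group in a tetradecyl amide series

This account rests on a few compounds, and the source may have more. Where it says the series, first, only, none or still open, it means among the compounds named here.

Compound 1 `CCCCCCCCCCCCCCNC(=O)[C@H](CO)/N=C/c1ccccc1O` gives 19000 nM
Compound 2 `CCCCCCCCCCCCCCNC(=O)[C@H](CO)NCc1ccccc1Cl` gives 43700 nM

In a functional assay on cells (Homo sapiens) for cytotoxicity, read by MTT assay, with a stated time of 24 h (a higher number here means a weaker inhibitor, a lower number a stronger inhibitor), compound 2 stands highest of the two at 43700 nM and is the weaker inhibitor, while compound 1 lies lower at 19000 nM on the same scale.

Compound 3 `CCCCCCCCCCCCCCNC(=O)[C@H](CO)/N=C/c1cccc(O)c1` differs from compound 2 in one place: a group of 9 heavy atoms (7 carbon, 1 nitrogen, 1 oxygen; one six-membered aromatic ring of carbon only) in place of a group of 9 heavy atoms (7 carbon, 1 nitrogen, 1 chlorine; one six-membered aromatic ring of carbon only), on a saturated chain carbon bound to a carbonyl carbon and a saturated chain carbon and the (2-chlorobenzyl)amino group leaves.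

Among the compounds with values here, only one measured step bears on this change. Within the data shown here, it is a 2.3-fold higher number from compound 1 to compound 2 (0.36 log units; beyond the scatter) and it put the same (2-chlorobenzyl)amino group in place of a group with the same make-up as the one entering compound 3. Among the measured compounds shown here, the two oxygen-bearing groups are not identical, and no measured step compares them, so this evidence is indirect. Running that change the other way suggests a modest move towards a lower number in this assay for the new compound. The expected change is a 2.2-fold lower number from compound 2 to compound 3 (0.34 log units; beyond the scatter) and it is only an estimate.

Compound 3 is expected to give 20000 nM (estimated range 9000 nM to 45000 nM) when measured.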

Compound 3, half-maximal inhibitory concentration: 32600 nM
Beside the measured number, compound 3's estimate is 1.6-fold (0.21 log units) below it, and the stated range covers the measured number.
By their numbers in this assay, from the lowest: compounds 1, 3 and 2 (each within the scatter of the next, the first and the last beyond it).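

In this assay, the exchange of the (2-chlorobenzyl)amino group for the hydroxyl-bearing group of compound 3 on a saturated chain carbon bound to a carbonyl carbon and a saturated chain carbon gives a 1.3-fold lower number from compound 2 to compound 3 (0.13 log units; within the scatter), so this exchange, unlike the earlier one that brought in 2-hydroxyphenyl, does not separate the two compounds. Placing 3-hydroxyphenyl in place of 2-hydroxyphenyl on a carbon with a double bond to nitrogen gives a 1.7-fold higher number from compound 1 to compound 3 (0.23 log units; within the scatter), which also stays inside the usual variation and shows that, for these two placings of the hydroxyl group, the assay draws no distinction. Compound 3 thus lies within the scatter of both neighbours, and no measurement shown offers any explanation of these numbers.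

In the compounds shown, the change from chlorine to oxygen and the double bond to nitrogen always occur together, so a (2-hydroxybenzyl)amino group at the same place would be needed to tell them apart. Also open, from the compounds shown here alone, are how a 4-hydroxyphenyl group would read here, and whether a dodecyl chain in place of tetradecyl would move these numbers.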